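A Larger Ring Group in a Level Series

The source may report more compounds than this note shows. Statements on the series, on what has been measured and on what is new or still open speak of the compounds shown alone.

In a functional assay on HUVEC cells (Homo sapiens), read by scintillation counting and thymidine incorporation, with a stated time of 24 h (a lower number here means a stronger inhibitor, a higher number a weaker inhibitor), three compounds sharing one core have been measured. Compound 1 `CCC(C)n1ncn(-c2ccc(N3CCN(c4ccc(OC[C@@H]5COC(c6ccc(Cl)cc6Cl)O5)cc4)CC3)cc2)c1=O` gives 328 nM, compound 2 `CCC(C)n1ncn(-c2ccc(N3CCN(c4ccc(OC[C@@H]5CO[C@@](CC)(c6ccc(Cl)cc6Cl)O5)cc4)CC3)cc2)c1=O` gives 353 nM, and compound 3 `CCC(C)n1ncn(-c2ccc(N3CCN(c4ccc(OC[C@@H]5CO[C@@](Cn6cnc(C)n6)(c6ccc(Cl)cc6Cl)O5)cc4)CC3)cc2)c1=O` gives 272 nM. These numbers lie within the scatter of one another, so compound 3 stands level with the other two.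

Compound 4 `CCC(C)n1ncn(-c2ccc(N3CCN(c4ccc(OC[C@@H]5CO[C@@](Cn6ccnc6-c6ccccc6)(c6ccc(Cl)cc6Cl)O5)cc4)CC3)cc2)c1=O` keeps the core of compound 3 and alters one group: 2-phenyl-1H-imidazol-1-yl in place of 3-methyl-1H-1,2,4-triazol-1-yl on a saturated chain carbon bound to a saturated ring carbon. Here, 2-phenyl-1H-imidazol-1-yl comes in place of 3-methyl-1H-1,2,4-triazol-1-yl on a saturated chain carbon bound to a saturated ring carbon.

Among the measured compounds shown here, only one measured step bears on this place: a 1.3-fold lower number from compound 2 to compound 3 (0.11 log units; within the scatter), where 3-methyl-1H-1,2,4-triazol-1-yl came in place of methyl. Even that exchange of a plain methyl for a ring stayed within the scatter. For the measured compounds named here, this is thin evidence, since it is a single step and no measured compound carries a phenyl on this side group.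

The step expected in this assay is therefore a 1.1-fold higher number from compound 3 to compound 4 (0.04 log units; within the scatter), with no change beyond the scatter. For compound 4 the estimated value is 300 nM, with an expected range from 130 nM to 700 nM.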

Compound 4, half-maximal inhibitory concentration: 136 nM
Compound 4: middle estimate off by 2.2-fold (0.34 log units), on the high side; the measured number falls inside the stated range.
By their numbers in this assay, from the lowest: compounds 4, 3, 1 and 2 (each within the scatter of the next, the first and the last beyond it).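

In this assay, the place on a saturated chain carbon bound to a saturated ring carbon accepts a much larger group: replacing 3-methyl-1H-1,2,4-triazol-1-yl by 2-phenyl-1H-imidazol-1-yl, which has more heavy atoms, gives a 2.0-fold lower number from compound 3 to compound 4 (0.30 log units; within the scatter) and so brings no loss. Among the compounds shown here, measured against the plain methyl, the same group gives a 2.6-fold lower number from compound 2 to compound 4 (0.41 log units; beyond the scatter) and is the first change at this place to pass the scatter, though only modestly, while the triazole group alone stayed within it. Nothing available here accounts for this step.

The compounds shown do not separate the part played by the phenyl ring from that of the imidazole ring, which a plain 1H-imidazol-1-yl group at this place could help to do. From the compounds shown here alone, it also remains open how a different kind of group, such as an amine or a carboxylic acid, would fare here, and whether a methoxy group on the added phenyl ring would shift the number further.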